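A few compounds are considered here, and "the series" means these few. Any claim that something is new, unique, unknown or untested is made for them only; others in the source may bear on it.

Measured in a functional assay on DU-145 cells (Homo sapiens) for inhibition, read by MTT assay, with stated times of 18 h and 4 h; on this read-out lower numbers stand for stronger inhibition and higher numbers for weaker inhibition:
- compound 1 `CCCCCCCCOP(=O)(O)OCCSC(=S)N1CCCCC1`: > 100000 nM (a limit)
- compound 2 `CCCCCCCCCCOP(=O)(O)OCCSC(=S)N1CCCCC1`: 29300 nM
- compound 3 `CCCCCCOP(=O)(O)OCCSC(=S)N1CCCCC1`: > 100000 nM (a limit)

Compound 3 stands at > 100000 nM, which is a limit of this assay and not a number. Compound 1 shares that limit, as the limit of > 100000 nM in this assay, at which 2 of the 3 values shown sit, records. Compound 4 `CCCCCCCCCCCCCCCCOP(=O)(O)OCCSC(=S)N1CCCCC1` has the same core as compound 3 and carries a much longer chain: decyl in place of hydrogen on a saturated chain carbon, six bonds along the chain from an oxygen on an unsaturated carbon.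

Going by the values given here, two measured steps bear on this change, both in chain length. Lengthening the chain gave an at least 3.4-fold lower number from compound 1 to compound 2 (0.53 log units; beyond the scatter). Shortening it gave an at least 3.4-fold higher number from compound 2 to compound 3 (0.53 log units; beyond the scatter). The remaining step, a step that the two limits leave unreadable from compound 1 to compound 3, adds nothing. Among these three compounds, only the one with the longest chain gives a number, and none goes against that trend. However, no chain as long as that of compound 4 has been measured, so the range must stay wide.

A move to a lower number is therefore expected, beyond the usual scatter. The expected step is an at least 10-fold lower number from compound 3 to compound 4 (1.00 log units; beyond the scatter). For compound 4, the estimate is 10000 nM, with an expected range of 2000 nM to 50000 nM.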

Compound 4, half-maximal inhibitory concentration: 14700 nM
Compound 4: the middle estimate sits 1.5-fold (0.17 log units) below what was measured; the range from low to high includes it.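

In this assay, the long chain of compound 4 still gives a real number, and the steps up to it are clear: an at least 6.8-fold lower number from compound 3 to compound 4 (0.83 log units; beyond the scatter) and an at least 6.8-fold lower number from compound 1 to compound 4 (0.83 log units; beyond the scatter). Compound 1 and compound 3 each stand at a limit and not a number, so these two steps give only minimum sizes: the limit of > 100000 nM in this assay, at which 2 of the 4 values shown sit. What the earlier compounds did not show is that adding hexyl to the chain gives a 2.0-fold lower number from compound 2 to compound 4 (0.30 log units; within the scatter), so the gain seen with chain length is not shown to continue past compound 2.

On these data alone, a chain of in-between length, or one longer than that of compound 4, remains open. So does whether a chain carrying an amine or a carboxylic acid would behave like these plain chains.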